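Compound 3: piperidin-4-yl on the chain

A few compounds are considered here, and "the series" means these few. Any claim that something is new, unique, unknown or untested is made for them only; others in the source may bear on it.

In an ADME assay on microsomes from liver (Rattus norvegicus) for metabolic stability, using NADPH, with a stated time of 10 min (a higher number here means that more of the compound is left, a lower number that less of the compound is left), compound 1 (`NCCCCN(C[C@H]1Cc2ncccc2CN1)[C@H]1CCCc2cccnc21`) gives 64% and compound 2 (`CN(CCCCN(C[C@H]1Cc2ncccc2CN1)[C@H]1CCCc2cccnc21)C1CCC(F)(F)CC1`) stands lowest of the two at 8%. Compound 3 (`c1cnc2c(c1)CN[C@@H](CN(CCCC1CCNCC1)[C@H]1CCCc3cccnc31)C2`) differs from compound 2 by one change (a group of 6 heavy atoms (5 carbon, 1 nitrogen; one six-membered non-aromatic ring with 1 hetero atom) in place of a group of 11 heavy atoms (8 carbon, 1 nitrogen, 2 fluorine; one six-membered non-aromatic ring of carbon only), on a saturated chain carbon, three bonds along the chain from an amine nitrogen). Among the compounds with values here, the only measured step that bears on it is large (a number 56 percentage points lower from compound 1 to compound 2 (beyond the scatter)), and the group entering there holds the six-membered non-aromatic ring of carbon only that leaves here. Piperidin-4-yl is not the lone nitrogen atom of compound 1, so only part of that step is expected to return. The expected step is upward and large (a number 32 percentage points higher from compound 2 to compound 3 (beyond the scatter)). Compound 3 is expected at 40% (range 18% to 65%).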

Compound 3, percent of the compound remaining: 40%
Compound 3: middle estimate and measured number agree at the digits printed, and the stated range covers the measured number.
By their numbers in this assay, from the lowest: compound 2; then compound 3; then compound 1.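

In this assay, a ring on this saturated chain carbon does not by itself give a number as low as compound 2's: with piperidin-4-yl in place of the larger group, the step is a number 32 percentage points higher from compound 2 to compound 3 (beyond the scatter). The ring still falls short of aminomethyl, the step being a number 24 percentage points lower from compound 1 to compound 3 (beyond the scatter).

Open, on these data alone, is which part of the exchange carries the rise, the ring nitrogen or the loss of the two fluorine atoms and the chain amine; a cyclohexyl group or an N-methylpiperidin-4-yl group at this place would help separate them. No measurement at hand gives a reason for either step.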